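The source may hold more compounds than are shown below. What is called first, only, known or untested is meant among the compounds shown, and "the series" means these compounds.

Compound 1 `Nc1ccccc1NC(=O)c1ccc(CSC(=S)N2CCN(c3ccccc3)CC2)cc1`: 73.1%
Compound 2 `COc1ccc(N2CCN(C(=S)SCc3ccc(C(=O)Nc4ccccc4N)cc3)CC2)cc1`: 52.3%
Compound 3 `Nc1ccccc1NC(=O)c1ccc(CSC(=S)N2CCN(Cc3ccncc3)CC2)cc1`: 72.9%

All three share one core and differ only in the group carried on an amine nitrogen in a six-membered non-aromatic ring with two nitrogens. In a functional assay on HeLa cells (Homo sapiens) for antiproliferative activity, read by CCK-8 assay, with a stated time of 72 h, tested at 8 uM (on this read-out lower numbers stand for a weaker effect and higher numbers for a stronger effect at the one concentration tested), compound 3 stands second highest of the three; its value lies within the scatter of that of compound 1, so the two cannot be told apart, while compound 2 sits clearly lower, as the step of a number 20.6 percentage points higher from compound 2 to compound 3 (beyond the scatter) shows.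

Compound 4 `Cc1ccc(N2CCN(C(=S)SCc3ccc(C(=O)Nc4ccccc4N)cc3)CC2)cc1` has not yet been measured. The change from compound 3 is 4-methylphenyl in place of (pyridin-4-yl)methyl on an amine nitrogen in a ring. Among the measured compounds shown here, two measured steps bear on it. The step of a number 0.2 percentage points lower from compound 1 to compound 3 (within the scatter) shows that exchanging phenyl for (pyridin-4-yl)methyl changed nothing beyond the scatter, so returning to an aromatic group on that nitrogen need not cost much. Yet the step of a number 20.8 percentage points lower from compound 1 to compound 2 (beyond the scatter) shows that methoxy in place of hydrogen on an aromatic carbon lowered the read-out in this assay beyond the scatter, so 4-methylphenyl, which also carries a substituent, may land between the values of compound 1 and compound 2. Compound 4 is therefore expected to give 62%, within a range from 45% to 78%, an expected step of a number 10.9 percentage points lower from compound 3 to compound 4 (beyond the scatter) that is modest and downward.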

Compound 4, a percentage reported as inhibition, at one concentration (the size of the read-out at that concentration, not a potency): 24%
Compound 4: middle estimate off by 38 percentage points, on the high side, and the stated range ends above it.
By their numbers in this assay, from the lowest: compound 4; then compound 2; then compounds 3 and 1 (each within the scatter of the next).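

In this assay, adding a methyl group to the phenyl group gives a number 49.1 percentage points lower from compound 1 to compound 4 (beyond the scatter) and so sharply lowers the read-out, which shows that the group on this ring nitrogen matters far more than the matching values of compound 1 and compound 3 alone suggested. The identity of the substituent counts and not just its presence: methyl in place of methoxy gives a number 28.3 percentage points lower from compound 2 to compound 4 (beyond the scatter) even though both groups sit on an aromatic carbon of the phenyl ring, so adding a substituent does not carry one fixed cost. The exchange of (pyridin-4-yl)methyl for 4-methylphenyl gives a number 48.9 percentage points lower from compound 3 to compound 4 (beyond the scatter) with the same number of heavy atoms entering and leaving, so size counted in this way does not track the read-out, and no measurement here accounts for these differences.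

The compounds shown leave open how chloro, hydroxyl or amino on the same phenyl ring would behave. They also leave open whether a plain benzyl group would stay close to compound 3 or fall toward compound 4.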